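This account rests on a few compounds, and the source may have more. Where it says the series, first, only, none or still open, it means among the compounds named here.

In a functional assay on HL-60 cells (Homo sapiens) for antiproliferative activity, read by MTT assay, with a stated time of 72 h (on this read-out lower numbers stand for stronger inhibition and higher numbers for weaker inhibition), compound 1 `COc1cc(-n2ncnc2-c2ccc(C)cc2)cc(OC)c1OC` gives 90 nM and compound 2 `COc1ccc(-c2ncnn2-c2cc(OC)c(OC)c(OC)c2)cc1` gives 120 nM. The step between them is a 1.3-fold higher number from compound 1 to compound 2 (0.12 log units; within the scatter). Compound 3 `COc1cc(-n2ncnc2-c2cccc(Cl)c2)cc(OC)c1OC` gives no number, only a limit of > 10000 nM. The steps leading to this limit are large: an at least 110-fold higher number from compound 1 to compound 3 (2.04 log units; beyond the scatter), and an at least 83-fold higher number from compound 2 to compound 3 (1.92 log units; beyond the scatter). Compound 4 `COc1ccccc1-c1ncnn1-c1cc(OC)c(OC)c(OC)c1` keeps the shared core but carries 2-methoxyphenyl in place of 3-chlorophenyl on an aromatic carbon. The two large steps are the measured changes closest to this one, since each also concerns the 3-chlorophenyl. They suggest that losing this group could bring a much lower number. Among the compounds with values here, compound 2 also has a methoxy group and gives 120 nM, but as 4-methoxyphenyl, and no measured compound carries 2-methoxyphenyl. A move back towards the lower numbers is therefore expected to be only partial, and another limit remains possible. The expected change is an at least 6.6-fold lower number from compound 3 to compound 4 (0.82 log units; beyond the scatter). For compound 4, the estimated value is 1500 nM, with an expected range from 150 nM to 10000 nM.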

Compound 4, half-maximal inhibitory concentration: > 10000 nM
Compound 4 was reported as a limit; the forecaster's own chance of this, stated with the estimate: 35%; middle value at least 6.6-fold (0.82 log units) from the limit.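

In this assay, putting 2-methoxyphenyl in place of 4-methoxyphenyl gives an at least 83-fold higher number from compound 2 to compound 4 (1.92 log units; beyond the scatter), so a methoxy group on this phenyl ring does not by itself keep the activity. Against the 4-methylphenyl of the best-matched methyl compound, the change gives an at least 110-fold higher number from compound 1 to compound 4 (2.04 log units; beyond the scatter), so the large loss is no longer seen with 3-chlorophenyl alone: across these four compounds, the 4-methylphenyl and 4-methoxyphenyl groups give numbers, while 3-chlorophenyl and 2-methoxyphenyl do not. Compound 3 and compound 4 are both reported only as limits of the assay, so the step between them cannot be read: the limit of > 10000 nM in this assay, at which 2 of the 4 values shown sit.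

On these data alone, how far compound 3 and compound 4 lie beyond that limit remains open. So does whether an unsubstituted phenyl, or a phenyl carrying an ethoxy group, would give a measurable number at this position.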